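The source may hold more compounds than are shown below. What is called first, only, known or untested is meant among the compounds shown, and "the series" means these compounds.

Among the measured compounds shown here, in a functional assay on the whole organism (strain Hartley) for inhibition, with Cavia porcellus as the target, with stated times of 15 min and 2 min (a lower number here means that less compound is needed, a higher number that more compound is needed for the effect), compound 1 (`CCCCC1([C@@H](O)/C=C/C2CCC(=O)[C@@H]2CCCCCCC(=O)OCC)CCC1`) gives 0.032 mg/kg, the highest of the three numbers so far. Compound 2 (`CCCCC1([C@H](O)/C=C/C2CCC(=O)[C@@H]2CCCCCCC(=O)OCC)CCC1`) gives 0.0151 mg/kg, and compound 3 (`CCCCC1([C@H](O)/C=C/C2CCC(=O)[C@@H]2CCCCCCC(=O)O)CCC1`) gives 0.0024 mg/kg. Compound 4 (`CCCCC1([C@@H](O)/C=C/C2CCC(=O)[C@@H]2CCCCSCC(=O)OCC)CCC1`) has not been measured and differs from compound 1 in its chain: ((ethoxycarbonyl)methyl)sulfanyl in place of 2-(ethoxycarbonyl)ethyl on a saturated chain carbon, four bonds along the chain from a saturated ring carbon. The measured steps concern other places. The first, a 2.1-fold lower number from compound 1 to compound 2 (0.33 log units; beyond the scatter), involves a stereocentre, and the second, a 6.3-fold lower number from compound 2 to compound 3 (0.80 log units; beyond the scatter), puts hydrogen in place of ethyl. Compound 4 keeps the configuration and the ethyl group of compound 1, so neither step carries over, and no measurement tests this swap. Only a small change with no firm direction is therefore expected, shown as a 1.3-fold higher number from compound 1 to compound 4 (0.10 log units; within the scatter). Compound 4 is estimated at 0.04 mg/kg, with an expected range of 0.01 mg/kg to 0.15 mg/kg.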

Compound 4, dose for half-maximal effect: > 0.672 mg/kg
Compound 4: only a limit was reported; the forecaster's own chance of this, stated with the estimate: 5%; at least 16-fold (1.22 log units) between middle value and limit.
By their numbers in this assay, from the lowest: compound 3; then compound 2; then compound 1. At a limit, above all of these: compound 4.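

The earlier steps shown here involved a stereocentre and an ethyl group, and both were modest, whereas this chain position proves far more sensitive: an at least 21-fold higher number from compound 1 to compound 4 (1.32 log units; beyond the scatter). In this assay, compound 4 gives > 0.672 mg/kg, which is a limit of the assay and not a number. The entering ((ethoxycarbonyl)methyl)sulfanyl group holds as many heavy atoms as the leaving 2-(ethoxycarbonyl)ethyl, so matching that count does not preserve the result in this pair.

Still open, on these data alone, is whether the loss follows the sulfur itself or the changed chain as a whole. A chain carrying an ether oxygen or a sulfone in place of the sulfur could help separate the two.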